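The source may hold more compounds than are shown below. What is called first, only, known or untested is meant among the compounds shown, and "the series" means these compounds.

Compound 2 `COc1ccccc1-c1nnc(-c2sc(-c3cccnc3)nc2C)o1` stands on a common footing with the two other measured analogues of the shared core. In an ADME assay on HCT-116 cells (Homo sapiens) for cytotoxicity, read by MTT assay (a higher number here means that more compound is tolerated, a lower number that less compound is tolerated), compound 2 gives > 100 ug/mL, which is a limit of the assay and not a number. Compound 1 `Cc1nc(-c2cccnc2)sc1-c1nnc(Cc2ccccc2)o1` gives > 100 ug/mL in this assay, likewise a limit. Compound 3 `Cc1nc(-c2cccnc2)sc1-c1nnc(-c2cccc(Cl)c2Cl)o1` gives > 100 ug/mL, also a limit. The steps a step that the two limits leave unreadable from compound 1 to compound 2, a step that the two limits leave unreadable from compound 1 to compound 3 and a step that the two limits leave unreadable from compound 2 to compound 3 therefore cannot be sized, since the limit of > 100 ug/mL in this assay, at which 3 of the 3 values shown sit, holds every reading. Compound 4 `Cc1nc(-c2cccnc2)sc1-c1nnc(-c2ccccc2[N+](=O)[O-])o1` differs from compound 2 by nitro in place of methoxy on an aromatic carbon. Going by the values given here, no measured step reads on this change. Compound 4 is expected to sit at the same limit, so that a step that the limit leaves unreadable from compound 2 to compound 4 is expected to be no step beyond the scatter. The estimate for compound 4 is 150 ug/mL, with a range from 70 ug/mL to 400 ug/mL.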

Compound 4, half-maximal cytotoxic concentration: > 100 ug/mL
Compound 4 ended at the assay's limit; the forecaster's own chance of this, stated with the estimate: 85%; the middle value lies beyond the limit too.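

No new step can be read between compound 2 and compound 4, since each reading is a limit and not a number: the limit of > 100 ug/mL in this assay, at which 4 of the 4 values shown sit. The compounds shown leave open where any of them would truly read in this assay, and so whether nitro and methoxy differ there at all.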